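The source may hold more compounds than are shown below. What is called first, only, known or untested is meant among the compounds shown, and "the series" means these compounds.

For the measured compounds named here, in an ADME assay on Vero cells (Chlorocebus sabaeus) for cytotoxicity (a higher number here means that more compound is tolerated, a lower number that less compound is tolerated), compound 1 `CCCCCCCCCCSc1ncnc2c1ncn2C1CCCC1` gives 8.04 ug/mL and compound 3 `CCCCCCCCCCSc1nc(N)nc2c1ncn2CC` gives 12.3 ug/mL as the only two numbers so far, and they lie within the usual scatter of each other. For compound 2 `CC(C)Oc1[nH]c(N)nc2ncnc1-2` the entry reads "not determined" (no result reported) and holds no number. Compound 4 `CCCCCCCCCCSc1ncnc2c1ncn2CC(=O)OCC` is still unmeasured. It has (ethoxycarbonyl)methyl in place of cyclopentyl on an aromatic nitrogen and otherwise keeps the core of compound 1. Going by the values given here, no measured pair differs in one place only, but compound 3 at 12.3 ug/mL differs from compound 1 in more than one place and stays within the scatter of it. No step beyond the scatter is therefore expected in either direction, and the estimated step (a 1.1-fold higher number from compound 1 to compound 4 (0.05 log units; within the scatter)) is small. Compound 4 is expected at 9 ug/mL with 4 ug/mL to 20 ug/mL as the estimated range.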

Compound 4, half-maximal cytotoxic concentration: > 62.5 ug/mL
Compound 4: no number, only a limit; the forecaster's own chance of this, stated with the estimate: 5%; middle value at least 6.9-fold (0.84 log units) from the limit.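

In this assay, compound 4 gives > 62.5 ug/mL, which is a limit of the assay and not a number. For the compounds shown here, putting (ethoxycarbonyl)methyl in place of cyclopentyl on an aromatic nitrogen gives an at least 7.7-fold higher number from compound 1 to compound 4 (0.89 log units; beyond the scatter), the first step here that changes one place only and the first beyond the scatter. The full size of this step remains unknown: the limit of > 62.5 ug/mL in this assay, at which 1 of the 4 values shown sits.

The compounds shown leave open whether a carboxylic acid or an amide carried on the same methyl would behave like (ethoxycarbonyl)methyl. Nor do they separate the entry of the two oxygen atoms from the loss of the ring.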